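The source may hold more compounds than are shown below. What is called first, only, known or untested is meant among the compounds shown, and "the series" means these compounds.

In an ADME assay on MT4 cells (Homo sapiens) for cytotoxicity, read by MTT assay, with a stated time of 5 days (on this read-out lower numbers stand for higher toxicity in this test and higher numbers for lower toxicity in this test), compound 1 `Cc1cc(C)cc(S(=O)(=O)c2c(C(=O)N[C@@H]3CCNC3)[nH]c3ccc(Cl)cc23)c1` gives 37300 nM and compound 2 `Cc1cc(C)cc(S(=O)(=O)c2c(C(=O)NC3CN(Cc4cccnc4)C3)[nH]c3ccc(Cl)cc23)c1` gives 36000 nM, which is a 1.0-fold lower number from compound 1 to compound 2 (0.02 log units; within the scatter). Compound 3 `Cc1cc(C)cc(S(=O)(=O)c2c(C(=O)NC3CN(Cc4ccccc4F)C3)[nH]c3ccc(Cl)cc23)c1` is reported as > 238000 nM, which is a limit of the assay and not a number. Its steps from both other compounds put compound 3 at the high end of the three on this read-out.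

Compound 4 `Cc1cc(C)cc(S(=O)(=O)c2c(C(=O)NC3CN(CC(N)=O)C3)[nH]c3ccc(Cl)cc23)c1` is related to compound 3 by carbamoyl in place of 2-fluorophenyl on a saturated chain carbon bound to an amine nitrogen in a ring, so carbamoyl takes the place of 2-fluorophenyl and 2-fluorobenzyl becomes carbamoylmethyl. The closest guide is an at least 6.6-fold higher number from compound 2 to compound 3 (0.82 log units; beyond the scatter), a change at the same place. The step of an at least 6.3-fold higher number from compound 1 to compound 3 (0.80 log units; beyond the scatter) is similar in size. Within the data shown here, both are bounded on one side only, and no measured compound carries carbamoyl.

Losing 2-fluorophenyl is therefore expected to give a lower number in this assay, though probably not all the way back to the level of compound 2. The expected change is an at least 3.4-fold lower number from compound 3 to compound 4 (0.53 log units; beyond the scatter). For compound 4 the estimated value is 70000 nM. The estimated range for compound 4 runs from 25000 nM to 240000 nM.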

Compound 4, half-maximal cytotoxic concentration: 25500 nM
Compound 4: middle estimate off by 2.7-fold (0.44 log units), on the high side; low and high end bracket the measured number.
By their numbers in this assay, from the lowest: compounds 4, 2 and 1 (each within the scatter of the next). At a limit, above all of these: compound 3.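

Compound 3 is held at a limit of the assay and not a number: the limit of > 238000 nM in this assay, at which 1 of the 4 values shown sits. In this assay, carbamoyl in place of 2-fluorophenyl on the saturated chain carbon bound to the ring amine nitrogen gives an at least 9.3-fold lower number from compound 3 to compound 4 (0.97 log units; beyond the scatter), whereas carbamoyl in place of pyridin-3-yl gives a 1.4-fold lower number from compound 2 to compound 4 (0.15 log units; within the scatter). With a 1.5-fold lower number from compound 1 to compound 4 (0.17 log units; within the scatter) as well, compound 1, compound 2 and compound 4 sit at one level, so of the groups shown at this place, only the 2-fluorophenyl of compound 3 stands apart, and carbamoyl, which has no ring, reads like the pyridin-3-yl.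

As far as these compounds go, it remains open whether the higher number of compound 3 follows the fluorine or the benzene ring itself. From the compounds shown here alone, how a plain benzyl or a carboxylic acid at this place would read also remains open.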